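The source may hold more compounds than are shown below. What is called first, only, known or untested is meant among the compounds shown, and "the series" means these compounds.

In an ADME assay on RAW264.7 cells (Mus musculus) for cytotoxicity, read by MTT assay, with a stated time of 48 h (on this read-out lower numbers stand for stronger inhibition and higher numbers for weaker inhibition), compound 3 `CS(=O)(=O)Nc1ccc(NC(=O)c2ccc(Cl)cc2)cc1F` gives 22300 nM, the lowest of the two numbers reported. Compound 1 `Cc1cc(NC(=O)c2ccc(C#N)cc2)ccc1NS(C)(=O)=O` gives 171000 nM in this assay. For compound 2 `CS(=O)(=O)Nc1ccc(NC(=O)c2ccc(C#N)cc2)cc1Cl` this assay reports only a limit, > 250000 nM. Among the measured compounds shown here, the single step measured in one place, chloro in place of methyl on an aromatic carbon, runs an at least 1.4-fold higher number from compound 1 to compound 2 (0.16 log units; that floor lies within the scatter), and that step rests on (the limit of > 250000 nM in this assay, at which 1 of the 3 values shown sits). Compound 4 `CS(=O)(=O)Nc1ccc(NC(=O)c2ccc(C#N)cc2)cc1F` differs from compound 3 by cyano in place of chloro on an aromatic carbon. For the measured compounds named here, no measured step isolates this exchange. The nearest evidence is that compound 3, which carries chloro where compounds 1 and 2 carry cyano, gives the lowest number, while compound 1 gives a much higher number and compound 2 only a limit, though both also differ from compound 3 in the group on the other ring. On that basis a higher number is expected for compound 4 in this assay, with a step of a 5.4-fold higher number from compound 3 to compound 4 (0.73 log units; beyond the scatter). Compound 4 is therefore estimated at 120000 nM, with a range from 40000 nM to 250000 nM, and a limit rather than a number would not be surprising.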

Compound 4, half-maximal inhibitory concentration: > 250000 nM
Compound 4 was reported as a limit; the forecaster's own chance of this, stated with the estimate: 25%; at least 2.0-fold (0.31 log units) between middle value and limit.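

Cyano in place of chloro on an aromatic carbon, para to a large group, gives an at least 11-fold higher number from compound 3 to compound 4 (1.04 log units; beyond the scatter) in this assay, the first single exchange in these compounds that reads beyond the scatter, and it places the largest shift seen so far at this position. In the same assay, fluoro in place of methyl gives an at least 1.4-fold higher number from compound 1 to compound 4 (0.16 log units; that floor lies within the scatter), and this floor, like the earlier one for chloro in place of methyl, lies within the scatter and so shows no clear effect of that exchange on the other ring. The step from compound 2 to compound 4 cannot be read because both compounds are reported only as limits: the limit of > 250000 nM in this assay, at which 2 of the 4 values shown sit.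

From the compounds shown here alone, compound 4 is reported only as a limit, so the full size of its step from compound 3 stays open, as does whether the exchange of chloro and cyano would give a similar step with methyl in place of fluoro. The compounds shown also leave open how the number would move with an amine, a carboxylic acid or a methoxy group at the position that carries chloro in compound 3 and cyano in compound 4.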